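Phenyl for pyridinyl in a glucose-derived enone series

The source may report more compounds than this note shows. Statements on the series, on what has been measured and on what is new or still open speak of the compounds shown alone.

Measured compounds:
compound 1, `O=C(/C=C/c1ccccc1)C[C@@H]1O[C@H](CO)[C@@H](O[C@@H]2O[C@H](CO)[C@@H](O)[C@H](O)[C@H]2O)[C@H](O)[C@H]1O`, -16.3%
compound 2, `O=C(/C=C/c1ccc(Cl)cc1)C[C@@H]1O[C@H](CO)[C@@H](O)[C@H](O)[C@H]1O`, -25.3%
compound 3, `O=C(/C=C/c1cccnc1)C[C@@H]1O[C@H](CO)[C@@H](O)[C@H](O)[C@H]1O`, -8.1%

In an assay for inhibition of glucose-6-phosphatase catalytic subunit 1 (Rattus norvegicus), tested at 100 uM (on this read-out higher numbers stand for more inhibition at the one concentration tested (going by the name of the read-out) and lower numbers for less inhibition), compound 3 holds the highest of the three numbers; compound 1 lies a little lower, within the scatter, while compound 2 lies lower by a margin beyond the scatter. Going by the values given here, the one step between measured compounds is a number 17.2 percentage points higher from compound 2 to compound 3 (beyond the scatter). Compound 4 is `O=C(/C=C/c1ccccc1)C[C@@H]1O[C@H](CO)[C@@H](O)[C@H](O)[C@H]1O`, differing from compound 3 by phenyl in place of pyridin-3-yl on a double-bonded chain carbon bound to a double-bonded chain carbon. Among the compounds with values here, no measured step swaps these two groups, but compound 1, which carries phenyl, gives -16.3%, within the scatter of compound 3. The step of a number 6.9 percentage points lower from compound 3 to compound 4 (within the scatter) is therefore expected to be small, if anything downward, and compound 4 is estimated at -15%, between -35% and 5%.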

Compound 4, a percentage reported as inhibition, at one concentration (the size of the read-out at that concentration, not a potency): -49.7%
Estimate against measurement, compound 4: 34.7 percentage points above, outside the stated range (below it).
By their numbers in this assay, from the lowest: compound 4; then compounds 2, 1 and 3 (each within the scatter of the next, the first and the last beyond it).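

In this assay, going by these compounds alone, the ring on this double-bonded chain carbon counts for more than the earlier compounds showed: phenyl in place of pyridin-3-yl gives a large step (a number 41.6 percentage points lower from compound 3 to compound 4 (beyond the scatter)). Hydrogen in place of chloro on an aromatic carbon also goes downward (a number 24.4 percentage points lower from compound 2 to compound 4 (beyond the scatter)). So does hydrogen in place of 3,4,5-trihydroxy-6-(hydroxymethyl)oxan-2-yl on an oxygen on a saturated carbon (a number 33.4 percentage points lower from compound 1 to compound 4 (beyond the scatter)).

No measurement shown accounts for these steps. On these data alone, whether pyridin-4-yl at this place, or methoxy in place of chloro, would follow compound 3 or compound 4 remains open.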